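A few compounds are considered here, and "the series" means these few. Any claim that something is new, unique, unknown or untested is made for them only; others in the source may bear on it.

Compound 1 `ClCc1ccccc1Cn1cnc2c(Cl)nc(Cl)nc21` and compound 2 `ClCc1cccc(Cn2cnc3nc(Cl)nc(Cl)c32)c1` have both been tested in a functional assay on OVCAR-4 cells (Homo sapiens) for cytotoxicity, read by sulforhodamine B assay, with a stated time of 48 h; a lower number here means a stronger inhibitor of growth, a higher number a weaker inhibitor of growth. Compound 1 gives 1770 nM, and compound 2 gives 1580 nM. Compound 1 thus carries the higher of the two numbers, but the gap to compound 2 is within the scatter of repeated measurements, so the two values show no real difference between them.

Compound 3 `Nc1nc(Cl)c2ncn(Cc3ccccc3CCl)c2n1` has not yet been tested in this assay. It differs from compound 1 in one place: amino in place of chloro on an aromatic carbon, on an aromatic carbon of a six-membered aromatic ring with two nitrogen atoms, between two ring nitrogen atoms, meta to a chloro group and to a fused ring and para to a fused ring. For the measured compounds named here, no measured pair tells what such a change does on this core.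

For compound 3 a modest weakening is expected, with a 1.4-fold higher number from compound 1 to compound 3 (0.15 log units; within the scatter) as the step from compound 1. The expected value for compound 3 is 2500 nM, within a range of 800 nM to 8000 nM.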

Compound 3, concentration for 50% growth inhibition: 2460 nM
The estimate for compound 3 lay 1.0-fold (0.01 log units) above the measured number, and the stated range covers the measured number.
By their numbers in this assay, from the lowest: compounds 2, 1 and 3 (each within the scatter of the next).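

Compounds 1 and 2 both carry chloro at the aromatic carbon between two ring nitrogen atoms, so they said nothing about this position. In this assay, amino in place of chloro at that carbon gives a 1.4-fold higher number from compound 1 to compound 3 (0.14 log units; within the scatter), which shows that this exchange on the core of compound 1 leaves the number within the scatter, and that the chloro group at this carbon is not needed for growth inhibition at this level. Nothing available accounts for this result.

Still open, as far as these compounds go, is whether a dimethylamino group, a methoxy group or a plain hydrogen at this carbon would also leave the number in place. From the compounds shown here alone, it is equally open whether amino in place of chloro on the core of compound 2 would give a step of similar size.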